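Removing the methoxy: from compound 3 to compound 4

The source may hold more compounds than are shown below. What is called first, only, known or untested is meant among the compounds shown, and "the series" means these compounds.

Of the compounds shown here, three of one shared core have been tested in a functional assay on the whole organism (strain Wistar albino) for inhibition, with Rattus norvegicus as the target, read by paw edema, with stated times of 30 min and 3 h, at a dose of 20 mg/kg; a higher number here means more inhibition at the dose given (going by the name of the read-out), a lower number less inhibition. Compound 1 `Clc1ccc([C@H]2CC(c3ccccc3)=NN2c2ncc(Br)cn2)cc1` gives 78%. Compound 2 `Brc1ccc([C@H]2CC(c3ccccc3)=NN2c2ncc(Br)cn2)cc1` gives 76%, and the step of a number 2 percentage points lower from compound 1 to compound 2 (within the scatter) stays within the scatter. Compound 3 `COc1ccc([C@H]2CC(c3ccc(Cl)cc3)=NN2c2ncc(Br)cn2)cc1` gives 73%, the lowest of the three numbers, yet both compound 2 and compound 1 sit within the scatter of it. Compound 4 `Clc1ccc(C2=NN(c3ncc(Br)cn3)[C@@H](c3ccccc3)C2)cc1` differs from compound 3 by hydrogen in place of methoxy on an aromatic carbon. Within the data shown here, no measured step removes a methoxy; the only step, a number 2 percentage points lower from compound 1 to compound 2 (within the scatter), swaps one halogen for another and bears on this change only loosely, giving no ground to expect movement beyond the scatter. Compound 4 is therefore expected to show a step of no change at the digits printed from compound 3 to compound 4 (within the scatter), with an estimated value of 73%, ranging from 60% to 84%.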

Compound 4, a percentage reported as inhibition, in the whole organism at one dose (the size of the read-out at that dose, not a potency): 75%
Compound 4: middle estimate off by 2 percentage points, on the low side, and the stated range covers the measured number.
By their numbers in this assay, from the lowest: compounds 3, 4, 2 and 1 (each within the scatter of the next).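

In this assay, replacing the methoxy with hydrogen, para to a large group, gives a number 2 percentage points higher from compound 3 to compound 4 (within the scatter), so the two compounds cannot be told apart. The earlier compounds shown here only exchanged one halogen for another, whereas this pair shows that a bare phenyl at this place reads the same as 4-methoxyphenyl, with the methoxy oxygen gone. Nothing available explains this result.

As far as these compounds go, whether an amine or a carboxylic acid at this place would also stay within the scatter remains open. A single dose also leaves the potency of these compounds open.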